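Swapping the aryl group on a triazole-linked furanone scaffold

The source may report more compounds than this note shows. Statements on the series, on what has been measured and on what is new or still open speak of the compounds shown alone.

Of the compounds shown here, three sharing one core have been measured in a functional assay on SW-620 cells (Homo sapiens) for antiproliferative activity, read by MTT assay, with a stated time of 72 h; on this read-out higher numbers stand for weaker inhibition and lower numbers for stronger inhibition. Compound 1 `O=C1O[C@H]([C@@H](O)Cn2cc(-c3ccc(Br)cc3)nn2)C(OCc2ccccc2)=C1OCc1ccccc1` carries a 4-bromophenyl group on the triazole ring and gives 3760 nM. Compound 2 `CCCCc1cn(C[C@H](O)[C@H]2OC(=O)C(OCc3ccccc3)=C2OCc2ccccc2)nn1` carries a butyl chain there instead and gives 47500 nM. Compound 3 `CCCCCc1ccc(-c2cn(C[C@H](O)[C@H]3OC(=O)C(OCc4ccccc4)=C3OCc3ccccc3)nn2)cc1` carries a 4-pentylphenyl group and gives 12200 nM, which places it second highest of the three numbers: the step of a 3.2-fold higher number from compound 1 to compound 3 (0.51 log units; beyond the scatter) shows it weaker than compound 1, while the step of a 3.9-fold lower number from compound 2 to compound 3 (0.59 log units; beyond the scatter) shows it stronger than compound 2. The largest step among the three is a 13-fold higher number from compound 1 to compound 2 (1.10 log units; beyond the scatter).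

Compound 4 `COc1ccccc1-c1cn(C[C@H](O)[C@H]2OC(=O)C(OCc3ccccc3)=C2OCc2ccccc2)nn1` has not yet been measured. It differs from compound 3 in one place: 2-methoxyphenyl in place of 4-pentylphenyl on an aromatic carbon. Within the data shown here, the steps that bear on this change are those between the three measured compounds, which together suggest that an aromatic ring on the triazole is favoured over a plain chain and that a smaller substituent on that ring does not hurt. Because the step of a 3.2-fold higher number from compound 1 to compound 3 (0.51 log units; beyond the scatter) was modest, a modest move in the stronger direction is expected here, namely a 2.0-fold lower number from compound 3 to compound 4 (0.31 log units; beyond the scatter). Compound 4 is therefore estimated at 6000 nM, with a likely range from 2000 nM to 18000 nM in this assay.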

Compound 4, half-maximal inhibitory concentration: > 100000 nM
Compound 4: no number, only a limit; the forecaster's own chance of this, stated with the estimate: 5%; middle value at least 16-fold (1.22 log units) from the limit.
By their numbers in this assay, from the lowest: compound 1; then compound 3; then compound 2. At a limit, above all of these: compound 4.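

In this assay, compound 4 gives no number, only a limit: the limit of > 100000 nM in this assay, at which 1 of the 4 values shown sits.

The step of an at least 8.1-fold higher number from compound 3 to compound 4 (0.91 log units; beyond the scatter) shows that an aromatic ring at this position does not by itself keep the activity, since 2-methoxyphenyl and 4-pentylphenyl both carry one six-membered aromatic ring of carbon only. The step of an at least 2.1-fold higher number from compound 2 to compound 4 (0.32 log units; beyond the scatter) goes further and breaks the earlier trend of an aromatic ring doing better than a plain chain: compounds 1 and 3 follow that trend, while compound 4 goes against it, falling behind even the butyl group. The step of an at least 26-fold higher number from compound 1 to compound 4 (1.42 log units; beyond the scatter) marks the full span now seen at this one position, so the choice of group here matters far more than the first three compounds suggested.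

Still open, from the compounds shown here alone, is whether the loss goes with the methoxy group itself or with where it sits on the phenyl ring, as compound 4 differs from compounds 1 and 3 in both respects. A 4-methoxyphenyl group, a 2-bromophenyl group or a plain phenyl group at this position would help to separate the two.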